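From dichlorophenyl to dimethoxyphenyl in a cell assay

The compounds below may be only part of what the source reports. "The series", "measured", "known", "first", "only" and "open" are said of these compounds alone.

- Compound 1 `O=C(/C=C/c1cccc(Cl)c1Cl)Nc1cc2c(Nc3ccc(F)c(Cl)c3)ncnc2cc1O[C@H]1CCOC1` gives 30500 nM in a functional assay on HeLa cells (Homo sapiens) for cytotoxicity, read by MTT assay, with a stated time of 72 h; on this read-out lower numbers stand for stronger inhibition and higher numbers for weaker inhibition
- Compound 2 `COc1ccc(/C=C/C(=O)Nc2cc3c(Nc4ccc(F)c(Cl)c4)ncnc3cc2OC)cc1` gives "not determined" (no result reported) in this assay

Among the compounds with values here, compound 1 stands alone: its 30500 nM is the only number available in this assay and compound 2 has no result, so it cannot yet be ranked against anything. Compound 3 `COc1ccc(OC)c(/C=C/C(=O)Nc2cc3c(Nc4ccc(F)c(Cl)c4)ncnc3cc2O[C@H]2CCOC2)c1` keeps the core of compound 1 and differs in one place (2,5-dimethoxyphenyl in place of 2,3-dichlorophenyl on a double-bonded chain carbon bound to a double-bonded chain carbon), with 2,5-dimethoxyphenyl in place of 2,3-dichlorophenyl on a double-bonded chain carbon bound to a double-bonded chain carbon. Both groups hold one six-membered aromatic ring of carbon only. Within the data shown here, no measured pair shows what such a swap does, so the data favour no direction. The estimated change is a 1.2-fold lower number from compound 1 to compound 3 (0.07 log units; within the scatter) and so nothing expected beyond the usual scatter. For compound 3 the expected value is 26000 nM with a range from 8000 nM to 80000 nM on this estimate.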

Compound 3, half-maximal inhibitory concentration: 26800 nM
Estimate against measurement, compound 3: 1.0-fold (0.01 log units) below; measured number inside the range.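

Replacing 2,3-dichlorophenyl with 2,5-dimethoxyphenyl on a double-bonded chain carbon bound to a double-bonded chain carbon gives a 1.1-fold lower number from compound 1 to compound 3 (0.06 log units; within the scatter) in this assay, so the two compounds cannot be told apart in this test. This first measured pair therefore shows that this particular swap leaves no readable mark, even though the entering group has 2 hydrogen-bond acceptors where the leaving group has 0, and 10 heavy atoms against 8. No measurement is available that would explain this result.

Both groups shown hold one six-membered aromatic ring of carbon only, so it remains open whether any group at this place can move the number beyond the scatter. A group of another kind there, such as an amine or a carboxylic acid, would be a different test of this position.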